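Hydroxyphenyl placement on two related cores

The compounds below may be only part of what the source reports. "The series", "measured", "known", "first", "only" and "open" are said of these compounds alone.

Measured so far:
compound 1 `Oc1cccc(-c2cc(-c3ccc(F)cc3)cc(-c3cccc(O)c3)n2)c1`, 6310 nM
compound 2 `Oc1ccc(-c2cc(-c3ccc(F)cc3)cc(-c3cccc(O)c3)n2)cc1`, 5020 nM
compound 3 `Oc1cccc(-c2cc(-c3ccccc3C(F)(F)F)cc(-c3ccccc3O)n2)c1`, 9010 nM

Compound 1, compound 2 and compound 3 were run in a functional assay on HCT-15 cells (Homo sapiens) for inhibition; on this read-out lower numbers stand for stronger inhibition and higher numbers for weaker inhibition; compound 4 `Oc1ccc(-c2cc(-c3ccccc3C(F)(F)F)cc(-c3ccccc3O)n2)cc1` has not been. The change from compound 1 to compound 2 is 4-hydroxyphenyl in place of 3-hydroxyphenyl on an aromatic carbon. In this assay this gave a 1.3-fold lower number from compound 1 to compound 2 (0.10 log units; within the scatter). The same kind of change separates compound 3 from compound 4: 4-hydroxyphenyl in place of 3-hydroxyphenyl on an aromatic carbon. The surroundings of the site differ: in compound 1 the carbon is meta to a 3-hydroxyphenyl group and meta to a 4-fluorophenyl group, in compound 3 it is meta to a 2-(trifluoromethyl)phenyl group and meta to a 2-hydroxyphenyl group. How the core of compound 1 differs from the core of compound 3 is not broken down here. A step of similar size, a 1.3-fold lower number from compound 3 to compound 4 (0.10 log units; within the scatter), is expected because a 1.3-fold lower number from compound 1 to compound 2 (0.10 log units; within the scatter) stayed within the scatter. Compound 4 is therefore estimated at 7200 nM in this assay, expected between 3500 nM and 15000 nM.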

Compound 4, half-maximal inhibitory concentration: 8990 nM
Compound 4: the middle estimate sits 1.2-fold (0.10 log units) below what was measured; the range from low to high includes it.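

In this assay, 4-hydroxyphenyl in place of 3-hydroxyphenyl again leaves the number within the scatter on the second core, with a 1.0-fold lower number from compound 3 to compound 4 (0.00 log units; within the scatter). The two steps do not differ: the same change on two cores in this assay, a 1.3-fold lower number (0.10 log units; within the scatter) from compound 1 to compound 2 and a 1.0-fold lower number (0.00 log units; within the scatter) from compound 3 to compound 4, 1.3-fold (0.10 log units) apart, within the scatter of two such steps. The change therefore carries across these two cores as a step too small to read, but two pairs do not show that it would stay this small on another core, and they cannot separate a slight effect of hydroxyl placement from none.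

Still open, on these data alone, is whether an amine or a carboxylic acid in place of the hydroxyl would give a step beyond the scatter in this assay. As far as these compounds go, a 2-hydroxyphenyl group at this site also remains open.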